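Pentan-3-ylamino in place of the cyanoethyl-bearing amine

A few compounds are considered here, and "the series" means these few. Any claim that something is new, unique, unknown or untested is made for them only; others in the source may bear on it.

The measured compounds are:
compound 1, `CCN(CCC#N)c1nc(C)nc2c(-c3c(C)cc(OC)cc3OC)c(C)nn12`, which in an assay on cell membranes for displacement of a labelled ligand from corticotropin-releasing factor receptor 1 (Rattus norvegicus) (a higher number here means a weaker inhibitor, a lower number a stronger inhibitor), gives 2.48 nM;
compound 2, `CCN(CC)c1nc(C)nc2c(-c3cc(F)c(OC)cc3Cl)c(C)nn12`, which in this assay gives 1.64 nM;
compound 3, `CCC(CC)Nc1nc(C)nc2c(-c3cc(OC)c(OC)cc3Br)c(C)nn12`, which in this assay gives 6.08 nM.

Compound 1 stands second highest of the three numbers. Its nearest neighbour is compound 2, whose number is lower but within the scatter, so the two cannot be told apart. Compound 3 lies furthest, with a higher number beyond the scatter. Compound 4, `CCC(CC)Nc1nc(C)nc2c(-c3c(C)cc(OC)cc3OC)c(C)nn12`, is not yet measured in this assay; it differs from compound 1 in one place: (pentan-3-yl)amino in place of (2-cyanoethyl)(ethyl)amino on an aromatic carbon. For the measured compounds named here, no step between measured compounds is recorded for this change. Compound 3 carries the same entering group but on a different aryl ring, so its number and that of compound 1 only show that both lie in a narrow span. A small rise is expected, likely near the edge of the scatter, with the step from a 1.6-fold higher number from compound 1 to compound 4 (0.21 log units; within the scatter). Compound 4 is estimated at 4 nM, in the range 1.5 nM to 11 nM.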

Compound 4, half-maximal inhibitory concentration: 5 nM
Beside the measured number, compound 4's estimate is 1.3-fold (0.10 log units) below it; the range from low to high includes it.
By their numbers in this assay, from the lowest: compounds 2, 1, 4 and 3 (each within the scatter of the next, the first and the last beyond it).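

For the compounds shown here, the step in this assay gives the first comparison at this position in which only one group changes, with the aryl ring and the rest of the core of compound 1 held fixed. The a 2.0-fold higher number from compound 1 to compound 4 (0.30 log units; within the scatter) shows that, on this aromatic carbon between two ring nitrogen atoms, (pentan-3-yl)amino can stand in place of (2-cyanoethyl)(ethyl)amino, losing the nitrile and gaining a hydrogen-bond donor, without a change that can be told from the scatter. Nothing shown here offers an explanation for this result.

From the compounds shown here alone, whether the same swap gives a similar step on the aryl rings of compound 2 or compound 3 stays open. So does how a morpholine ring or a carboxylic acid-bearing chain would fare at this position.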